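Difluoroazepanone in place of trifluoromethylazepanone on the sulfonamide nitrogen

A few compounds are considered here, and "the series" means these few. Any claim that something is new, unique, unknown or untested is made for them only; others in the source may bear on it.

Compound 2 `O=C(NC1CC1)c1ccc(CN(C2CC(C(F)(F)F)CCNC2=O)S(=O)(=O)c2ccc(Cl)cc2)cc1` gives 19 mL.min-1.g-1 in an in vitro ADME assay on microsomes (Homo sapiens) for pharmacokinetics (on this read-out lower numbers stand for slow clearance and higher numbers for fast clearance), the highest of the three numbers; compound 1 `COc1ccc(CN([C@@H]2CC(F)(F)CCNC2=O)S(=O)(=O)c2ccc(Cl)cc2)c(F)c1` gives 13 mL.min-1.g-1, within the scatter of it, while compound 3 `COc1ccc(CN([C@@H]2CC(F)(F)CCNC2=O)S(=O)(=O)c2ccc(Cl)cc2)cn1` gives 9 mL.min-1.g-1, a gap beyond the scatter. Among the measured compounds shown here, the one measured step, a 1.4-fold lower number from compound 1 to compound 3 (0.16 log units; within the scatter), concerns the aryl group and does not bear on the present change. Compound 4 `O=C(NC1CC1)c1ccc(CN([C@@H]2CC(F)(F)CCNC2=O)S(=O)(=O)c2ccc(Cl)cc2)cc1` differs from compound 2 by 5,5-difluoro-2-oxoazepan-3-yl in place of 2-oxo-5-(trifluoromethyl)azepan-3-yl on a sulfonamide nitrogen. Compounds 1 and 3 already carry the 5,5-difluoro-2-oxoazepan-3-yl and sit at or under compound 2, so a modest downward step is expected, a 1.5-fold lower number from compound 2 to compound 4 (0.16 log units; within the scatter), within the scatter. Compound 4 is estimated at 13 mL.min-1.g-1, in the range 7 mL.min-1.g-1 to 25 mL.min-1.g-1.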

Compound 4, intrinsic clearance in microsomes: 1.9 mL.min-1.g-1
Compound 4: middle estimate off by 6.8-fold (0.84 log units), on the high side, outside the stated range (below it).
By their numbers in this assay, from the lowest: compound 4; then compounds 3, 1 and 2 (each within the scatter of the next, the first and the last beyond it).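

In this assay, the sulfonamide nitrogen substituent proves a sensitive position: 5,5-difluoro-2-oxoazepan-3-yl in place of 2-oxo-5-(trifluoromethyl)azepan-3-yl gives a 10-fold lower number from compound 2 to compound 4 (1.00 log units; beyond the scatter). Only the entering group has a defined stereocentre, so this step does not separate the change in fluorinated substituent from the change in stereochemical definition. Nothing available accounts for the size of the step.

Going by these compounds, it remains open whether the same replacement gives a similar step with the 2-fluoro-4-methoxyphenyl or 6-methoxypyridin-3-yl groups. On these data alone, the standing of 2-oxoazepan-3-yl without fluorine is also open.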